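Swapping the aryl group of compound 3

This account rests on a few compounds, and the source may have more. Where it says the series, first, only, none or still open, it means among the compounds named here.

Of the compounds shown here, three sharing one core have been measured in an assay with Cystic fibrosis transmembrane conductance regulator (Rattus norvegicus) as the target; a lower number here means tighter binding, a higher number weaker binding. Compound 1 `OCCc1cc(-c2ccccc2OCc2ccc(Br)cc2)no1` gives 23000 nM. Compound 3 `COC(=O)C1CC(c2ccccc2OCc2ccc(Br)cc2)=NO1` gives 73000 nM, the highest of the two numbers shown, with compound 1 lower by a margin beyond the scatter. For compound 2 `COCc1cc(-c2ccccc2OCc2ccc(Br)cc2)no1` this assay reports only a limit, > 300000 nM. Going by the values given here, the single measured step, an at least 13-fold higher number from compound 1 to compound 2 (1.11 log units; beyond the scatter), is large; it involves the limit of > 300000 nM in this assay, at which 1 of the 3 values shown sits, and concerns the group on the saturated chain carbon bound to an aromatic carbon, not the group on the saturated chain carbon bound to an oxygen on an aromatic ring.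

Compound 4 `COC(=O)C1CC(c2ccccc2OCc2cccc(OC)c2)=NO1` differs from compound 3 by 3-methoxyphenyl in place of 4-bromophenyl on a saturated chain carbon bound to an oxygen on an aromatic ring. Among the compounds with values here, no measured step touches that part of the molecule, so the data give no direction for this change, and the measured steps themselves are all at the other end of the core. Compound 4 is therefore expected to give about 73000 nM, between 25000 nM and 220000 nM. The step of no change at the digits printed from compound 3 to compound 4 (within the scatter) is expected to stay within the scatter.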

Compound 4, dissociation constant: 110000 nM
Beside the measured number, compound 4's estimate is 1.5-fold (0.18 log units) below it; low and high end bracket the measured number.
By their numbers in this assay, from the lowest: compound 1; then compounds 3 and 4 (each within the scatter of the next). At a limit, above all of these: compound 2.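

Going by these compounds alone, this is the first reading at the aryl group on a saturated chain carbon bound to an oxygen on an aromatic ring: in this assay, 3-methoxyphenyl in place of 4-bromophenyl gives a 1.5-fold higher number from compound 3 to compound 4 (0.18 log units; within the scatter), so the two groups cannot be told apart here. The earlier compounds shown here showed a step beyond the scatter only for the group on the saturated chain carbon bound to an aromatic carbon, whereas this one exchange shows none at the new place. Nothing shown bears on why the two aryl groups read alike.

Going by these compounds, the exchange alters both the substituent and where it sits on the phenyl ring, so it remains open how 3-bromophenyl or 4-methoxyphenyl would read. Also open, on these data alone, is whether an unsubstituted phenyl, or a phenyl carrying an amine or a carboxylic acid, would stay within the scatter of compound 3.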